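This account rests on a few compounds, and the source may have more. Where it says the series, first, only, none or still open, it means among the compounds named here.

In a functional assay on RXF 393 cells (Homo sapiens) for inhibition, read by sulforhodamine B assay, with a stated time of 48 h, tested at 1 uM (on this read-out higher numbers stand for a weaker effect at the one concentration tested and lower numbers for a stronger effect), three close relatives of one shared core have been measured. Compound 1 `O=C(Nc1cccc(-n2cc(-c3ccncc3)c(-c3cc(O)cc(Cl)c3)n2)c1)Nc1ccc(Cl)c(C(F)(F)F)c1` gives 58%. Compound 2 `O=C(Nc1cccc(-n2cc(-c3ccncc3)c(-c3cc(O)cc(Cl)c3)n2)c1)Nc1ccc(Cl)c(Cl)c1` gives 38%, and compound 3 `COc1cc(Cl)cc(-c2nn(-c3cccc(NC(=O)Nc4ccc(Cl)c(Cl)c4)c3)cc2-c2ccncc2)c1` gives 75%. Among these three numbers compound 3 stands highest, which here means the weakest effect at the single concentration tested: it lies a number 37 percentage points higher from compound 2 to compound 3 (beyond the scatter), and the gap between compound 1 and compound 3 is also beyond the scatter.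

Compound 4 `COc1cc(Cl)cc(-c2nn(-c3cccc(NC(=O)c4cccc(C(F)(F)F)c4)c3)cc2-c2ccncc2)c1` differs from compound 3 in one place: 3-(trifluoromethyl)phenyl in place of (3,4-dichlorophenyl)amino on a carbonyl carbon. The urea of compound 3 thereby becomes a plain amide, and the ring that enters carries a trifluoromethyl group instead of two chlorines.

Going by the values given here, no measured step swaps a (3,4-dichlorophenyl)amino for a 3-(trifluoromethyl)phenyl, so nothing bears on this change directly. The nearest hint is the modest shift of a number 20 percentage points lower from compound 1 to compound 2 (beyond the scatter), where chloro in place of trifluoromethyl gave a stronger effect; compound 4 moves the other way, toward trifluoromethyl, while also giving up the second chloro and a hydrogen-bond donor. The expectation is therefore a small rise, or no step beyond the scatter, as a number 7 percentage points higher from compound 3 to compound 4 (within the scatter). Compound 4 is estimated at 82%, within a range from 62% to 100%.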

Compound 4, a percentage reported as activity, at one concentration (the size of the read-out at that concentration, not a potency): 53%
Estimate against measurement, compound 4: 29 percentage points above; measured number below the stated range.
By their numbers in this assay, from the lowest: compound 2; then compounds 4 and 1 (each within the scatter of the next); then compound 3.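

On a carbonyl carbon whose other neighbour is an amide-type nitrogen, 3-(trifluoromethyl)phenyl in place of (3,4-dichlorophenyl)amino gives a number 22 percentage points lower from compound 3 to compound 4 (beyond the scatter) in this assay and so a stronger effect at the one concentration tested. Going by these compounds alone, all the earlier compounds keep the urea, so this is the first sign that, with the methoxy group of compound 3 in place, the effect does not depend on the amino nitrogen or its hydrogen-bond donor. This single step changes the link and the ring substituents together, and no measurement shown gives a reason for the stronger effect.

As far as these compounds go, what remains open is which part of the change matters: (3-(trifluoromethyl)phenyl)amino or 3,4-dichlorophenyl on the same carbonyl carbon would each change only one part, and a morpholine there would show whether an aromatic ring is needed at all. From the compounds shown here alone, it also remains open whether the same change would strengthen or weaken the effect with the hydroxyl group of compound 2 in place of the methoxy group.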